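Aryl substituent step from compound 1 to compound 3

A few compounds are considered here, and "the series" means these few. Any claim that something is new, unique, unknown or untested is made for them only; others in the source may bear on it.

For the measured compounds named here, compound 1 `CC1=CC[C@@H]([C@@](C)(O)CCCC(C)(C)NC(=S)N/N=C\c2ccccc2)CC1` gives 38400 nM in a functional assay on NCI-H460 cells (Homo sapiens) for cytotoxicity, read by sulforhodamine B assay (on this read-out lower numbers stand for stronger inhibition of growth and higher numbers for weaker inhibition of growth), the higher of the two numbers measured so far. Compound 2 `CC1=CC[C@@H]([C@@](C)(O)CCCC(C)(C)NC(=S)N/N=C\c2ccc(C)cc2)CC1` gives 10100 nM in this assay. Going by the values given here, the one step on record, a 3.8-fold lower number from compound 1 to compound 2 (0.58 log units; beyond the scatter), came with methyl in place of hydrogen on an aromatic carbon. Compound 3 `CC1=CC[C@@H]([C@@](C)(O)CCCC(C)(C)NC(=S)N/N=C\c2ccc(Cl)cc2)CC1` differs from compound 1 by chloro in place of hydrogen on an aromatic carbon. Among the compounds with values here, only that single step bears on it, so a modest step in the same direction, beyond the scatter, is expected. For compound 3 a value of 12000 nM is estimated, with a range of 5000 nM to 30000 nM, which would mean a step of a 3.2-fold lower number from compound 1 to compound 3 (0.51 log units; beyond the scatter).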

Compound 3, concentration for 50% growth inhibition: 8720 nM
Compound 3: the middle estimate sits 1.4-fold (0.14 log units) above what was measured; low and high end bracket the measured number.
By their numbers in this assay, from the lowest: compounds 3 and 2 (each within the scatter of the next); then compound 1.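

In this assay, chloro at this position, para to a large group, also gives a lower number (a 4.4-fold lower number from compound 1 to compound 3 (0.64 log units; beyond the scatter)), so the drop seen with methyl is not unique to that group. Chloro and methyl cannot be separated on this read-out (a 1.2-fold lower number from compound 2 to compound 3 (0.06 log units; within the scatter)), which leaves the two substituents equivalent within the scatter. Nothing at hand accounts for either step.

Going by these compounds, whether an amine, a carboxylic acid or a methoxy group at this position would give a similar number remains open. So does whether a larger group, such as a phenyl ring, would continue the drop.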